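Trading 2,4-difluorobenzyl for methyl

A few compounds are considered here, and "the series" means these few. Any claim that something is new, unique, unknown or untested is made for them only; others in the source may bear on it.

- compound 1 `C=C1C(=O)O[C@H]2[C@H]1CC/C(COC(=O)Cn1cc(F)c(=O)n(Cc3ccc(Cl)cc3)c1=O)=C\CC[C@@]1(C)O[C@@H]21` (2560 nM)
- compound 2 `C=C1C(=O)O[C@H]2[C@H]1CC/C(COC(=O)Cn1cc(F)c(=O)n(Cc3ccc([N+](=O)[O-])cc3)c1=O)=C\CC[C@@]1(C)O[C@@H]21` (4070 nM)
- compound 3 `C=C1C(=O)O[C@H]2[C@H]1CC/C(COC(=O)Cn1cc(F)c(=O)n(Cc3ccc(F)cc3F)c1=O)=C\CC[C@@]1(C)O[C@@H]21` (3670 nM)

Compound 1 and compound 2 both stay within the usual scatter of compound 3 (3670 nM) in a functional assay on Bel-7402 cells (Homo sapiens) for antiproliferative activity, read by MTT assay, with a stated time of 72 h (a lower number here means a stronger inhibitor, a higher number a weaker inhibitor), so the three form a single band with no meaningful order.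

Compound 4 `C=C1C(=O)O[C@H]2[C@H]1CC/C(COC(=O)Cn1cc(F)c(=O)n(C)c1=O)=C\CC[C@@]1(C)O[C@@H]21` carries hydrogen in place of 2,4-difluorophenyl on a saturated chain carbon bound to an aromatic nitrogen. The same difference can be read as 2,4-difluorobenzyl to methyl.

The measured steps bear on this change only in part. Altering the aromatic group gave a 1.6-fold higher number from compound 1 to compound 2 (0.20 log units; within the scatter) and a 1.4-fold higher number from compound 1 to compound 3 (0.16 log units; within the scatter) and a 1.1-fold lower number from compound 2 to compound 3 (0.04 log units; within the scatter) in these comparisons. Among the compounds with values here, all three keep the aromatic ring, and no measured compound lacks it, so the loss of the whole ring is untested. The small size of those steps gives no reason to predict a large shift in either direction, but it offers only weak support. The expected result is no change beyond the scatter, estimated as a 1.1-fold higher number from compound 3 to compound 4 (0.04 log units; within the scatter) in this reading. Allowing for the untested change, compound 4 is estimated at 4000 nM (expected range 1500 nM to 11000 nM).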

Compound 4, half-maximal inhibitory concentration: 9400 nM
For compound 4 the middle estimate is 2.4-fold (0.37 log units) below the measured one; measured number inside the range.
By their numbers in this assay, from the lowest: compounds 1, 3 and 2 (each within the scatter of the next); then compound 4.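

Losing the aromatic ring at this position is the only change among these compounds that moves the number beyond the scatter in this assay. Replacing 2,4-difluorobenzyl with methyl gives a 2.6-fold higher number from compound 3 to compound 4 (0.41 log units; beyond the scatter), and the same replacement of the other two benzyl groups gives a 2.3-fold higher number from compound 2 to compound 4 (0.36 log units; beyond the scatter) and a 3.7-fold higher number from compound 1 to compound 4 (0.56 log units; beyond the scatter). Changing the groups on the ring left compound 1, compound 2 and compound 3 in one band, so among these four compounds the presence of a ring on the saturated chain carbon bound to an aromatic nitrogen matters more than its substituents, although all three steps are only modest, and no supporting measurement here explains why the number rises when the ring is gone.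

The compounds shown go directly from benzyl groups to methyl, so they cannot separate the contribution of the aromatic ring from that of the carbon chain attached to the nitrogen. A propyl or butyl chain, a cyclohexylmethyl group or an unsubstituted benzyl group would help to settle this, and a benzyl ring carrying an amine or a carboxylic acid would test the range of substituents further.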